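The source may hold more compounds than are shown below. What is called first, only, known or untested is meant among the compounds shown, and "the series" means these compounds.

Compound 1 `CCCSc1nc(N/N=C(\C)c2ccccc2O)c2nnn(Cc3ccco3)c2n1` serves as the reference point. In a functional assay on ECa-109 cells (Homo sapiens) for antiproliferative activity, read by MTT assay, with a stated time of 72 h (on this read-out lower numbers stand for stronger inhibition and higher numbers for weaker inhibition), compound 1 gives 5760 nM, the lowest of the two numbers shown. Compound 2 `CCCSc1nc(N/N=C/c2ccc([N+](=O)[O-])cc2)c2nnn(Cc3ccccc3)c2n1` gives 6640 nM in this assay, a value within the scatter of compound 1, so the two cannot be ordered. Compound 3 `CCCSc1nc(N/N=C/c2ccccc2)c2nnn(Cc3ccccc3)c2n1` returns only a limit in this assay, > 64000 nM, and no number. One of the three results is therefore (the limit of > 64000 nM in this assay, at which 1 of the 3 values shown sits). Within the data shown here, the single measured step, an at least 9.6-fold higher number from compound 2 to compound 3 (0.98 log units; beyond the scatter), concerns a substituent on an aromatic carbon elsewhere in the molecule and is beyond the scatter, but it does not touch the group on the saturated chain carbon bound to an aromatic nitrogen.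

Compound 4 `CCCSc1nc(N/N=C(\C)c2ccccc2O)c2nnn(Cc3ccc(Cl)cc3)c2n1` differs from compound 1 by 4-chlorophenyl in place of furan-2-yl on a saturated chain carbon bound to an aromatic nitrogen. No measured pair varies this position, so no shown step bears directly on it; the expectation for this assay is a step no larger than the scatter, with no direction favoured, namely a 1.0-fold lower number from compound 1 to compound 4 (0.02 log units; within the scatter). Compound 4 is thus estimated at 5500 nM, within a range from 1800 nM to 17000 nM.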

Compound 4, half-maximal inhibitory concentration: 11200 nM
Compound 4: the middle estimate sits 2.0-fold (0.31 log units) below what was measured; the measured number falls inside the stated range.
By their numbers in this assay, from the lowest: compounds 1, 2 and 4 (each within the scatter of the next). At a limit, above all of these: compound 3.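

The saturated chain carbon bound to an aromatic nitrogen now has its first measured pair: in this assay, 4-chlorophenyl in place of furan-2-yl gives a 1.9-fold higher number from compound 1 to compound 4 (0.29 log units; within the scatter) and the two compounds cannot be ordered. On this pair, the read-out does not separate the five-membered aromatic ring with its oxygen from the six-membered carbon ring carrying chlorine. No measured property shown here bears on this step.

From the compounds shown here alone, whether a carboxylic acid, an amine or a longer alkyl chain at this position would give a step beyond the scatter remains open. Also open, going by these compounds, is how a plain benzyl group would read on the core of compound 1, so any separate contributions of the ring and the chlorine cannot be told apart.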